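Swapping the Para Substituent: From Dimethylcarbamoyl to Methoxy

The source may report more compounds than this note shows. Statements on the series, on what has been measured and on what is new or still open speak of the compounds shown alone.

Measured so far:
- Compound 1 `CC(C)Oc1ccc(CNC(=O)c2ccc(C(C)(C)C)cc2)cc1`: 170 nM
- Compound 2 `CN(C)C(=O)c1ccc(CNC(=O)c2ccc(C(C)(C)C)cc2)cc1`: 170 nM
- Compound 3 `O=C(O)c1ccc(CNC(=O)c2ccc(-c3ccccc3)cc2)cc1`: 440 nM

All three compounds share a core in which a benzylamine is joined through an amide to a second aromatic ring, and they were tested in an assay on HeLa cells with Bile acid receptor (Homo sapiens) as the target, read by a luciferase reporter, with a stated time of 24 h; on this read-out higher numbers stand for an effect only at larger amounts of compound and lower numbers for an effect already at smaller amounts. On this read-out compound 2 stands level with compound 1, the two together giving the lowest numbers of the three; compound 3 sits furthest away, and its higher number lies beyond the usual scatter.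

The next compound, compound 4 `COc1ccc(CNC(=O)c2ccc(C(C)(C)C)cc2)cc1`, differs from compound 2 in one place: methoxy in place of dimethylcarbamoyl on an aromatic carbon. Within the data shown here, only one measured step is informative here. The change from compound 1 to compound 2 swapped an isopropoxy for a dimethylcarbamoyl at the same place, and it gave no change at the digits printed from compound 1 to compound 2 (within the scatter). Since the reverse direction, back to an oxygen-linked group, is what compound 4 represents, with a methoxy instead of an isopropoxy, the expectation is no step beyond the scatter, a 1.2-fold higher number from compound 2 to compound 4 (0.07 log units; within the scatter).

The estimate for compound 4 is therefore 200 nM, with a range from 80 nM to 500 nM.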

Compound 4, half-maximal effective concentration: 150 nM
For compound 4 the middle estimate is 1.3-fold (0.12 log units) above the measured one; the range from low to high includes it.
By their numbers in this assay, from the lowest: compounds 4, 1 and 2 (each within the scatter of the next); then compound 3.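

In this assay, replacing dimethylcarbamoyl, with its 5 heavy atoms and a double bond outside the aromatic ring, by methoxy, with 2 heavy atoms, gives a 1.1-fold lower number from compound 2 to compound 4 (0.05 log units; within the scatter), so this large change in the group on the aromatic carbon, para to a large group, leaves no effect that can be told from the scatter. The new compound also allows a smaller change within the oxygen-linked groups, methyl in place of isopropyl on the oxygen, which gives a 1.1-fold lower number from compound 1 to compound 4 (0.05 log units; within the scatter), and so compounds 1, 2 and 4 now show three different groups at this place with numbers that all lie within the scatter of one another. No measurement available here explains why these groups read alike.

From the compounds shown here alone, it remains open whether this flat picture would hold for an amine, a hydroxyl group or a longer chain such as butoxy on the core shared by compounds 1, 2 and 4. Compound 3 differs from these compounds in more than one place, so its number cannot be assigned to this position alone.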